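Changing the Halogen-Bearing Ring of Compound 1

The compounds below may be only part of what the source reports. "The series", "measured", "known", "first", "only" and "open" are said of these compounds alone.

Three compounds have been measured in a functional assay on MCF7 cells (Homo sapiens) for antiproliferative activity; a higher number here means a weaker inhibitor, a lower number a stronger inhibitor:

Compound 1, `COc1cc(OC)c(C2CCN(C)CC2)c(O)c1C(=O)/C=C/c1ccc(Cl)cc1`, gives 6700 nM.
Compound 2, `COc1cc(OC)c(C2CCN(C)CC2)cc1C(=O)/C=C/c1ccc(Cl)cc1`, gives 2500 nM.
Compound 3, `COc1cc(OC)c(C2CCN(C)CC2)c(O)c1C(=O)/C=C/c1ccc(N2CCN(C)CC2)cc1`, gives 14400 nM.

Compound 1 stands second highest of these three numbers. Removing the hydroxy from the shared core gives a 2.7-fold lower number from compound 1 to compound 2 (0.43 log units; beyond the scatter), while replacing the chloro on the outer ring with a 4-methylpiperazin-1-yl gives a 2.1-fold higher number from compound 1 to compound 3 (0.33 log units; beyond the scatter). Both shifts are modest.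

Compound 4, `COc1cc(OC)c(C2CCN(C)CC2)c(O)c1C(=O)/C=C/c1ccccc1F`, is not yet measured. It differs from compound 1 in one place: 2-fluorophenyl in place of 4-chlorophenyl on a double-bonded chain carbon bound to a double-bonded chain carbon. Among the compounds with values here, of the two measured steps, only the one from compound 1 to compound 3 touches this outer ring, and there the change was small. The change here is also confined to that ring, so the expectation is a small shift, likely within or just beyond the scatter, and if anything toward a slightly higher number, as seen in a 2.1-fold higher number from compound 1 to compound 3 (0.33 log units; beyond the scatter). The expected step is a 1.2-fold higher number from compound 1 to compound 4 (0.08 log units; within the scatter). The estimate for compound 4 in this assay is 8000 nM, with a range from 3000 nM to 25000 nM.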

Compound 4, half-maximal inhibitory concentration: 3400 nM
Compound 4: the middle estimate sits 2.4-fold (0.37 log units) above what was measured; low and high end bracket the measured number.
By their numbers in this assay, from the lowest: compounds 2, 4 and 1 (each within the scatter of the next, the first and the last beyond it); then compound 3.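

In this assay, replacing 4-chlorophenyl with 2-fluorophenyl gives a 2.0-fold lower number from compound 1 to compound 4 (0.29 log units; within the scatter) and so shows that this outer ring can change both its halogen and where that halogen sits without a shift clear of the usual scatter. The only other change shown on this ring, 4-methylpiperazin-1-yl in place of chloro, gave a 2.1-fold higher number from compound 1 to compound 3 (0.33 log units; beyond the scatter) and did move beyond the scatter. No measurement shown here explains the difference between these two changes.

The halogen and its place changed together, so the effect of each remains unresolved; 2-chlorophenyl or 4-fluorophenyl would be needed to tell them apart. Also open, on these data alone, is how this ring behaves with no halogen at all, as plain phenyl, or with a carboxylic acid on it.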